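Removing a Methyl Group from Compound 1

This account rests on a few compounds, and the source may have more. Where it says the series, first, only, none or still open, it means among the compounds named here.

Three measured compounds share a common core. Compound 1 `COc1cc(-c2nc(C(c3ccc(F)cc3)c3ccc(F)cc3)sc2CC(=O)O)ccn1` reaches 60% in an in vitro functional assay on HEK285-7 cells for antagonist activity at prostaglandin D2 receptor 2 (Homo sapiens), read by BRET and beta-arrestin recruitment; on this read-out higher numbers stand for larger maximal responses and lower numbers for smaller maximal responses. Compound 2 `O=C(O)Cc1sc(CSc2ccccc2)nc1-c1ccc(Cl)cc1` gives 50% in this assay, and compound 3 `O=C(O)Cc1sc(NC(=O)c2ccccc2)nc1-c1ccc(Cl)cc1` gives 50% in this assay. Compound 1 has the highest of the three numbers, yet the gaps to compound 2 and to compound 3 both fall within the usual scatter of repeated measurements, so the three compounds cannot be ordered on these data.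

Compound 4 `O=C(O)Cc1sc(C(c2ccc(F)cc2)c2ccc(F)cc2)nc1-c1ccnc(O)c1` has not yet been measured in this assay. Compared with compound 1 it carries hydrogen in place of methyl on an oxygen on an aromatic ring. Read one bond further out, this is methoxy to hydroxy, or 2-methoxypyridin-4-yl to 2-hydroxypyridin-4-yl. Among the compounds with values here, no measured pair in this set differs by this change alone, so no measured step tells its size. Within the data shown here, the three known numbers all lie within scatter of one another. The step expected for this change, a number 5 percentage points lower from compound 1 to compound 4 (within the scatter), is therefore estimated as small, not beyond the scatter, with no clear direction. Compound 4 is expected to reach about 55% in this assay, with an estimated range from 35% to 75%.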

Compound 4, largest response reached (reported as efficacy), in percent of the reference or control that the assay uses: 60%
The estimate for compound 4 lay 5 percentage points below the measured number; low and high end bracket the measured number.
By their numbers in this assay, from the lowest: compounds 2, 3, 1 and 4 (each within the scatter of the next).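

Going from methoxy to hydroxy on the 2-methoxypyridin-4-yl group, with hydrogen in place of methyl on an oxygen on an aromatic ring, gives no change at the digits printed from compound 1 to compound 4 (within the scatter) in this assay. Within the data shown here, this is the first step in the set in which only one place differs, and it shows that the methyl group can leave this oxygen without a shift that stands out from the scatter of this read-out. No measurement here offers an explanation for this outcome.

The finding rests on a single pair and a single change, so it describes only the exchange of methyl for hydrogen on this oxygen and cannot be extended to other places on the shared core. Whether a longer chain such as ethyl on the same oxygen, or an amine in place of the methoxy group, would also leave the number within the scatter of compound 1 remains open, since the compounds shown contain no such group at this place.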